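Methoxy in Place of Fluoro on a Porcupine Inhibitor

The compounds below may be only part of what the source reports. "The series", "measured", "known", "first", "only" and "open" are said of these compounds alone.

Compound 1 `O=C(CNC(=O)c1nn(-c2ccccc2)c(=O)c2ccccc12)Nc1nc2ccc(F)cc2s1` is assessed in an assay on L cells for inhibition of Protein-serine O-palmitoleoyltransferase porcupine (Mus musculus), read by reporter gene assay, with a stated time of 24 h (a higher number here means that more compound is needed for the effect, a lower number that less compound is needed), where it gives 470 nM. For the measured compounds named here, that is the highest of the three numbers measured so far. Compound 2 `O=C(CSc1nc2c(c(=O)n1-c1ccccc1)SCC2)Nc1ccc(-c2ccncc2)cc1` gives 3 nM in this assay, and compound 3 `O=C(CSc1nc2c(c(=O)n1-c1ccccc1)SCC2)Nc1ccc(-c2cccs2)cn1` gives 0.3 nM; both are built on a different core from compound 1, so the gaps to compound 1 cannot be tied to any single change. Compound 4 `COc1ccc2nc(NC(=O)CNC(=O)c3nn(-c4ccccc4)c(=O)c4ccccc34)sc2c1` has not yet been measured. It differs from compound 1 at one place on an aromatic ring: methoxy in place of fluoro on an aromatic carbon. Going by the values given here, no measured pair shows what this exchange does, so the step of a 1.2-fold lower number from compound 1 to compound 4 (0.07 log units; within the scatter) is expected to be small, in either direction or none beyond the scatter. Compound 4 is therefore expected to give about 400 nM, within a range from 150 nM to 1200 nM.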

Compound 4, half-maximal effective concentration: 210 nM
The estimate for compound 4 lay 1.9-fold (0.28 log units) above the measured number; the range from low to high includes it.
By their numbers in this assay, from the lowest: compound 3; then compound 2; then compound 4; then compound 1.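

On the core of compound 1, this position accepts a change of substituent: in this assay, replacing fluoro with methoxy gives a 2.2-fold lower number from compound 1 to compound 4 (0.35 log units; beyond the scatter). For the compounds shown here, the two extra heavy atoms of the methoxy group therefore bring a modest gain rather than a loss, which the earlier compounds, with no matched pair, could not show. No measurement here explains why the number moves. Still open, on these data alone, is whether an amine, a hydroxyl or a longer chain such as ethoxy at this position would lower the number further.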